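Azido to amino on the saturated chain carbon

A few compounds are considered here, and "the series" means these few. Any claim that something is new, unique, unknown or untested is made for them only; others in the source may bear on it.

In a functional assay on CCRF-CEM cells (Homo sapiens) for inhibition (on this read-out higher numbers stand for weaker inhibition and lower numbers for stronger inhibition), compound 1 (`O=c1[nH]c(=O)n(C2O[C@H](CCl)[C@@H](O)[C@H]2O)cc1F`) gives 22000 nM, compound 2 (`O=c1[nH]c(=O)n(C2O[C@H](CBr)[C@@H](O)[C@H]2O)cc1F`) gives 3100 nM and compound 3 (`[N-]=[N+]=NC[C@H]1OC(n2cc(F)c(=O)[nH]c2=O)[C@H](O)[C@@H]1O`) gives 350000 nM. Compound 3 therefore has the highest number of the three and is the weakest inhibitor. The next compound is compound 4 (`NC[C@H]1OC(n2cc(F)c(=O)[nH]c2=O)[C@H](O)[C@@H]1O`), with the change amino in place of azido on a saturated chain carbon bound to a saturated ring carbon.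

Three measured steps at this place bear on the change. Bromo in place of chloro gives a 7.1-fold lower number from compound 1 to compound 2 (0.85 log units; beyond the scatter), azido in place of chloro gives a 16-fold higher number from compound 1 to compound 3 (1.20 log units; beyond the scatter), and azido in place of bromo gives a 110-fold higher number from compound 2 to compound 3 (2.05 log units; beyond the scatter). All lie beyond the scatter, but none involves amino, so the direction is uncertain. Both other groups measured here give lower numbers than azido, so a move down in this assay is expected, with no change still possible. The expected size is a 2.9-fold lower number from compound 3 to compound 4 (0.46 log units; beyond the scatter). The estimate for compound 4 is 120000 nM, with an expected range of 20000 nM to 600000 nM.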

Compound 4, half-maximal inhibitory concentration: 49000 nM
Estimate against measurement, compound 4: 2.4-fold (0.39 log units) above, and the stated range covers the measured number.
By their numbers in this assay, from the lowest: compound 2; then compound 1; then compound 4; then compound 3.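

In this assay, within the data shown here, amino in place of azido gives a 7.1-fold lower number from compound 3 to compound 4 (0.85 log units; beyond the scatter), the first step at this position that moves away from azido without a halogen entering. Amino does not reach the halogens, however: amino in place of bromo gives a 16-fold higher number from compound 2 to compound 4 (1.20 log units; beyond the scatter), and amino in place of chloro gives a 2.2-fold higher number from compound 1 to compound 4 (0.35 log units; beyond the scatter), so the four groups now rank from lowest to highest number as bromo, chloro, amino, azido, with every printed step beyond the scatter. No measurement here accounts for this order.

Still open, going by these compounds, is whether iodo on the same carbon would extend the drop in number seen from chloro to bromo. It is also unknown whether a hydroxyl, a methylamino group or a longer chain ending in an amine would fall nearer amino or the halogens.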